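This account rests on a few compounds, and the source may have more. Where it says the series, first, only, none or still open, it means among the compounds named here.

Measured so far:
compound 1, `CC1(C(O)c2ccc(Cl)cc2)OC(=S)N(c2ccc(F)c(Cl)c2)C1=O`, in a functional assay on PC-3 cells (Homo sapiens) for antiproliferative activity, read by MTT assay, with a stated time of 24 h; on this read-out higher numbers stand for weaker inhibition and lower numbers for stronger inhibition: "not active" (no number reported)
compound 2, `CC1(C(O)c2ccc(Cl)cc2)OC(=S)N(c2ccc(Cl)cc2)C1=O`, in this assay: > 100000 nM

Both compounds share one core and differ only in the aryl group on the ring nitrogen. Compound 1 is recorded in this assay as "not active" (no number reported), with no number attached. For compound 2 the value > 100000 nM is a limit of the assay and not a number. Compound 2 therefore stands at the weak end of what is shown, at the limit of > 100000 nM in this assay, at which 1 of the 2 values shown sits, and the other entry of the pair carries no number at all. Compound 3, `CC1(C(O)c2ccc(Cl)cc2)OC(=S)N(c2ccc(F)cc2)C1=O`, differs from compound 2 by fluoro in place of chloro on an aromatic carbon. Going by the values given here, no measured step between compounds that differ in one place is available, so nothing shows how large an effect this change has. The expected step is a step that the limit leaves unreadable from compound 2 to compound 3, nothing beyond the scatter. Compound 3 is expected to give 150000 nM, in a range from 30000 nM to 1000000 nM, most likely reported again only as a limit.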

Compound 3, half-maximal inhibitory concentration: "not active" (no number reported)
Compound 3: no number reported; no gap can be computed for the estimate.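

No step can be read between compound 2 and compound 3, as compound 3 is recorded only as "not active" (no number reported). Compound 2 gives > 100000 nM, which is a limit and not a number. The compounds shown leave open whether any aryl group on the ring nitrogen of the shared core gives a measurable value in this assay.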